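The compounds below may be only part of what the source reports. "The series", "measured", "known", "first", "only" and "open" are said of these compounds alone.

In a functional assay on SK-MEL-5 cells (Homo sapiens) for antiproliferative activity (on this read-out lower numbers stand for stronger inhibition of growth and higher numbers for weaker inhibition of growth), compound 1 (`COCCCCCCCCCCC/C=C1\CC(CO)(COC(=O)C(C)(C)C)OC1=O`) gives 2.81 ug/mL and compound 2 (`COC(=O)CCCCCCCCCCCCCC/C=C1\CC(CO)(COC(=O)C(C)(C)C)OC1=O`) gives 7.8 ug/mL. Compound 3 (`CC(C)(C)C(=O)OCC1(CO)C/C(=C\CCCCCCCCCCCCCCC=O)C(=O)O1`) reads > 10 ug/mL, which is a limit and not a number. Only compound 3 sits at the limit of > 10 ug/mL in this assay, at which 1 of the 3 values shown sits.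

Compound 4 (`CC(C)(C)C(=O)OCCCCCCCCCCCCCCC/C=C1\CC(CO)(COC(=O)C(C)(C)C)OC1=O`) differs from compound 3 at the end of the chain: (((tert-butyl)carbonyl)oxy)methyl in place of formyl on a saturated chain carbon, ten or more bonds along the chain from a double-bonded chain carbon. It carries (((tert-butyl)carbonyl)oxy)methyl in place of formyl on a saturated chain carbon, ten or more bonds along the chain from a double-bonded chain carbon.

The closest measured comparison is an at least 1.2-fold higher number from compound 2 to compound 3 (0.10 log units; that floor lies within the scatter), so a change at this chain end has not been shown to matter once the methoxy end of compound 1 is gone. The two steps away from that methoxy end are larger: a 2.8-fold higher number from compound 1 to compound 2 (0.44 log units; beyond the scatter) and an at least 3.5-fold higher number from compound 1 to compound 3 (0.55 log units; beyond the scatter). Neither involves the incoming group. In this assay, no step beyond the scatter is therefore expected, and the expected step is an at least 1.1-fold lower number from compound 3 to compound 4 (0.04 log units; that floor lies within the scatter). Compound 4 is estimated at 9 ug/mL, with an expected range from 4 ug/mL to 20 ug/mL.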

Compound 4, concentration for 50% growth inhibition: 3.46 ug/mL
Estimate against measurement, compound 4: 2.6-fold (0.42 log units) above; measured number outside the range, below it.
By their numbers in this assay, from the lowest: compounds 1 and 4 (each within the scatter of the next); then compound 2. At a limit, above all of these: compound 3.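

In this assay, the group at this chain end proves to matter, which the earlier step between compounds 2 and 3 could not show: there is an at least 2.8-fold lower number from compound 3 to compound 4 (0.46 log units; beyond the scatter), and there is a 2.3-fold lower number from compound 2 to compound 4 (0.35 log units; beyond the scatter). Leaving the methoxy end of compound 1 therefore does not in itself bring a higher number, since there is only a 1.2-fold higher number from compound 1 to compound 4 (0.09 log units; within the scatter). The reading for compound 3 is a limit and not a number, so its step gives only a floor: the limit of > 10 ug/mL in this assay, at which 1 of the 4 values shown sits.

The compounds shown leave open how a hydroxyl, a carboxylic acid or an amine would read at this chain end. They also leave open whether the (((tert-butyl)carbonyl)oxy)methyl end would hold its reading on a shorter chain.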